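Notes on chloro in place of fluoro

The source may hold more compounds than are shown below. What is called first, only, known or untested is meant among the compounds shown, and "the series" means these compounds.

compound 1 `CCOC(=O)c1nn(-c2ccccc2)c(-c2ccc(Cl)cc2)c1CNC(C)(C)C`: 72400 nM; > 559000 nM (2 entries)
compound 2 `CC(C)(C)NCc1c(C(=O)O)nn(-c2ccccc2)c1-c1ccc(F)cc1`: > 680000 nM

In a functional assay on MCF7 cells (Homo sapiens) for inhibition, read by sulforhodamine B assay, with a stated time of 48 h (on this read-out lower numbers stand for stronger inhibition of growth and higher numbers for weaker inhibition of growth), compound 1 gives 72400 nM; > 559000 nM (2 entries). The second entry of compound 1 is a limit and not a number. In this assay compound 2 gives only a limit, > 680000 nM, with one further entry that carries no single number.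

Compound 3 `CC(C)(C)NCc1c(C(=O)O)nn(-c2ccccc2)c1-c1ccc(Cl)cc1` departs from compound 2 in one place: chloro in place of fluoro on an aromatic carbon. Going by the values given here, no measured step shows what this change does. In this assay no change beyond the scatter is expected, and the estimated step is an at least 1.1-fold lower number from compound 2 to compound 3 (0.05 log units; that floor lies within the scatter). For compound 3 the expected value is 600000 nM, with an estimated range from 200000 nM to 800000 nM, and a report as a limit is the likelier outcome.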

Compound 3, concentration for 50% growth inhibition: > 652000 nM
Compound 3: no number, only a limit; the forecaster's own chance of this, stated with the estimate: 80%; at least 1.0-fold (0.03 log units) between middle value and limit.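

Going by these compounds alone, compound 2 and compound 3 are each reported only as a limit and not as a number, so no step between them can be read. The compounds shown leave open whether 4-fluorophenyl to 4-chlorophenyl changes inhibition of growth at all, and by how much.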